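A Fluoro Analogue of Compound 1

A few compounds are considered here, and "the series" means these few. Any claim that something is new, unique, unknown or untested is made for them only; others in the source may bear on it.

Compound 1 `CC(=O)Nc1cccc(Cn2cc(-c3ccc4cn[nH]c4c3)ccc2=O)c1` gives 43 nM in an assay for inhibition of MAP kinase-interacting serine/threonine-protein kinase 2 (Homo sapiens), read by luminescence and ADP-Glo, with a stated time of 2 h (on this read-out lower numbers stand for stronger inhibition and higher numbers for weaker inhibition), the highest of the two numbers shown, while compound 2 `CC(=O)Nc1cccc(Cn2cc(-c3ccc4c(N)n[nH]c4c3)ccc2=O)c1` gives 8 nM. Within the data shown here, the only measured step, a 5.4-fold lower number from compound 1 to compound 2 (0.73 log units; beyond the scatter), concerns a different place on the shared core. Compound 3 `O=c1ccc(-c2ccc3cn[nH]c3c2)cn1Cc1cccc(F)c1` differs from compound 1 by fluoro in place of acetamido on an aromatic carbon. Among the measured compounds shown here, no measured step bears on this exchange, so the expectation rests only on what is counted in the group that leaves and the group that enters. On that basis the expected step is a 3.0-fold higher number from compound 1 to compound 3 (0.48 log units; beyond the scatter), a weakening beyond the scatter. Compound 3 is estimated at 130 nM, with a range from 40 nM to 450 nM.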

Compound 3, half-maximal inhibitory concentration: 38 nM
Estimate against measurement, compound 3: 3.4-fold (0.53 log units) above, and the stated range ends above it.
By their numbers in this assay, from the lowest: compound 2; then compounds 3 and 1 (each within the scatter of the next).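

Fluoro in place of acetamido on this aromatic carbon, meta to a large group, gives a 1.1-fold lower number from compound 1 to compound 3 (0.05 log units; within the scatter). The acetamido group, with its hydrogen-bond donor and acceptor, is therefore not required at this position to keep the number seen with compound 1, and fluoro serves equally well here. Nothing shown accounts for why the two groups read alike.

Still open, going by these compounds, is whether plain hydrogen, an amine or a carboxylic acid on this carbon would also read alike. On these data alone, it is also open whether the amino step seen from compound 1 to compound 2 would carry over to the fluoro series.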